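The source may report more compounds than this note shows. Statements on the series, on what has been measured and on what is new or still open speak of the compounds shown alone.

Working notes on the series. All three measured compounds share one core and differ only at one aromatic carbon of the five-membered ring. Compound 1 `CCCCC#Cc1cc([C@@H]2O[C@H](CO)[C@@H](O)[C@H]2O)n2ncnc(N)c12` carries butyl on a triple-bonded carbon; in a functional assay on HCT-116 cells (Homo sapiens) for antiproliferative activity, with a stated time of 72 h (on this read-out higher numbers stand for weaker inhibition and lower numbers for stronger inhibition), compound 1 gives 2900 nM. Compound 2 `Nc1ncnn2c([C@@H]3O[C@H](CO)[C@@H](O)[C@H]3O)cc(C#CC3CC3)c12` carries cyclopropyl there; in this assay compound 2 gives 50 nM, the step being a 58-fold lower number from compound 1 to compound 2 (1.76 log units; beyond the scatter). Compound 3 `Nc1ncnn2c([C@@H]3O[C@H](CO)[C@@H](O)[C@H]3O)cc(C#Cc3ccccc3)c12` carries phenyl on the triple-bonded carbon; in this assay compound 3 gives 46900 nM, the highest of the three numbers, reached by a 16-fold higher number from compound 1 to compound 3 (1.21 log units; beyond the scatter) and by a 940-fold higher number from compound 2 to compound 3 (2.97 log units; beyond the scatter).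

The next compound is compound 4 `Nc1ncnn2c([C@@H]3O[C@H](CO)[C@@H](O)[C@H]3O)cc(-c3ccccc3F)c12`: 2-fluorophenyl in place of 2-phenylethynyl on an aromatic carbon. Among the measured compounds shown here, no measured step covers a 2-fluorophenyl bound directly to this aromatic carbon, nor the loss of the triple bond, so none bears on the change directly. For the measured compounds named here, the three measured steps show only that every change at this aromatic carbon has moved the number far beyond the scatter, in both directions. Compound 3 sits at the weak end, so room remains for a lower number, but the direction cannot be read from the steps shown. For compound 4 a modest lowering is expected, a 3.1-fold lower number from compound 3 to compound 4 (0.50 log units; beyond the scatter), with wide uncertainty. The estimate for compound 4 in this assay is 15000 nM, within 1500 nM to 100000 nM.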

Compound 4, half-maximal inhibitory concentration: > 100000 nM
Compound 4 gave a limit, no number (the forecaster's own chance of this, stated with the estimate: 15%); at least 6.6-fold (0.82 log units) between middle value and limit.
By their numbers in this assay, from the lowest: compound 2; then compound 1; then compound 3. At a limit, above all of these: compound 4.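

In this assay, compound 4 stands at a limit of the assay and not at a number: the limit of > 100000 nM in this assay, at which 1 of the 4 values shown sits. Setting 2-fluorophenyl directly on this aromatic carbon gives an at least 2.1-fold higher number from compound 3 to compound 4 (0.32 log units; beyond the scatter), an at least 34-fold higher number from compound 1 to compound 4 (1.53 log units; beyond the scatter) and an at least 2000-fold higher number from compound 2 to compound 4 (3.30 log units; beyond the scatter), and each of these steps is a minimum, since its far end is a limit. The earlier compounds showed only groups carried on a triple bond, whereas compound 4 shows that a directly bound aromatic ring also reads at the weak end, so among these four compounds the two with a six-membered aromatic ring, compound 3 and compound 4, lie at the weak end, and the two with butyl or cyclopropyl on the triple-bonded carbon, compound 1 and compound 2, give lower numbers, with no compound shown going against this.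

The step from compound 3 to compound 4 removes the triple bond and adds the fluorine together, so the compounds shown do not separate the two changes, and a plain phenyl bound directly to this carbon would be needed to do so. Also open, on these data alone, is how a small chain such as ethyl, or an amine on a short chain, would read on the triple-bonded carbon, given the wide gap between butyl and cyclopropyl there.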